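The source may hold more compounds than are shown below. What is called first, only, known or untested is meant among the compounds shown, and "the series" means these compounds.

Three compounds have been measured in an ADME assay on HEK-293T cells (Homo sapiens) for cytotoxicity, read by MTT assay, with a stated time of 24 h; on this read-out lower numbers stand for higher toxicity in this test and higher numbers for lower toxicity in this test:

compound 1 `Cc1ccc(-c2nn(-c3ccccc3)cc2-c2nc3ccccc3n2C(=O)c2ccc(C)nc2)cc1`: 145000 nM
compound 2 `Cc1ccc(-c2nn(-c3ccccc3)cc2-c2nc3ccccc3n2C(=O)c2cncc(C)c2)cc1`: 155000 nM
compound 3 `Cc1cncc(C(=O)n2c(-c3cn(-c4ccccc4)nc3-c3ccc(C(F)(F)F)cc3)nc3ccccc32)c1`: 123000 nM

Compound 2 cannot be told apart from its neighbours on these numbers: the step of a 1.1-fold higher number from compound 1 to compound 2 (0.03 log units; within the scatter) and the step of a 1.3-fold lower number from compound 2 to compound 3 (0.10 log units; within the scatter) both lie within the scatter, so the three values read as one level. Compound 4 `Cc1ccc(-c2nn(-c3ccccc3)cc2-c2nc3ccccc3n2C(=O)c2cccc(C)c2)cc1` differs from compound 2 by 3-methylphenyl in place of 5-methylpyridin-3-yl on a carbonyl carbon. Among the measured compounds shown here, no measured step exchanges a pyridyl for a phenyl at the carbonyl carbon; the only steps that bear on this region, a 1.1-fold higher number from compound 1 to compound 2 (0.03 log units; within the scatter) at the same carbonyl and a 1.3-fold lower number from compound 2 to compound 3 (0.10 log units; within the scatter) on the remote ring, were both within the scatter. Compound 4 is therefore expected to show no step beyond the scatter, a 1.1-fold lower number from compound 2 to compound 4 (0.03 log units; within the scatter), in this assay. The estimate for compound 4 is 145000 nM, with a range from 70000 nM to 300000 nM.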

Compound 4, half-maximal cytotoxic concentration: 195000 nM
Estimate against measurement, compound 4: 1.3-fold (0.13 log units) below; measured number inside the range.
By their numbers in this assay, from the lowest: compounds 3, 1, 2 and 4 (each within the scatter of the next).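

In this assay, compound 4 is the only one shown with a ring of carbon only on the carbonyl carbon, and replacing the nitrogen-bearing ring gives a 1.3-fold higher number from compound 2 to compound 4 (0.10 log units; within the scatter) and a 1.3-fold higher number from compound 1 to compound 4 (0.13 log units; within the scatter). Removing the ring nitrogen at this position, from either methylpyridinyl group, therefore moves the number no further than the scatter. As far as these compounds go, whether an amine or a carboxylic acid in place of the methyl on this ring would shift the number beyond the scatter remains open. No measurement shown offers an explanation for these results.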